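The compounds below may be only part of what the source reports. "The series", "measured", "known", "first", "only" and "open" are said of these compounds alone.

Measured so far in a functional assay for agonist activity at Free fatty acid receptor 1 (Homo sapiens); on this read-out higher numbers stand for an effect only at larger amounts of compound and lower numbers for an effect already at smaller amounts:
compound 1, `O=C(O)C1CC1c1ccc(NCc2cccc(Oc3ccccc3)c2)cc1`, gives 50.1 nM;
compound 2, `Cc1ccc(CNc2ccc(CCC(=O)O)cc2)cc1`, gives 3980 nM.

For the measured compounds named here, of these two numbers, compound 2 carries the higher one, and its only neighbour, compound 1, sits far lower, well beyond the usual scatter. Compound 3, `O=C(O)CCc1ccc(NCc2ccc(Oc3ccccc3)cc2)cc1`, has not been measured. It differs from compound 2 in one place: phenoxy in place of methyl on an aromatic carbon. Compound 1, which also carries a phenoxy group, gives 50.1 nM, so a sizeable step downward in this assay is expected for compound 3, a 13-fold lower number from compound 2 to compound 3 (1.12 log units; beyond the scatter). The estimate for compound 3 is 300 nM, within a range from 80 nM to 1200 nM.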

Compound 3, half-maximal effective concentration: 195 nM
Compound 3: the middle estimate sits 1.5-fold (0.19 log units) above what was measured; low and high end bracket the measured number.
By their numbers in this assay, from the lowest: compound 1; then compound 3; then compound 2.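

In this assay, phenoxy in place of methyl on this aromatic carbon gives a 20-fold lower number from compound 2 to compound 3 (1.31 log units; beyond the scatter), a large step. This position therefore accepts a much bigger group, one bringing an extra aromatic ring, and the number still falls rather than rises. Nothing on hand speaks to the reason for this drop. The compounds shown leave open whether the ring or the oxygen carries the change: a phenyl group has no oxygen link, and a methoxy group has no ring, so either could separate the two.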